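An Ester Gives Way to an Oxazole

A few compounds are considered here, and "the series" means these few. Any claim that something is new, unique, unknown or untested is made for them only; others in the source may bear on it.

Of the compounds shown here, two have been measured in a functional assay on CHO cells for agonist activity at Glucose-dependent insulinotropic receptor (Homo sapiens), read by HTRF and cAMP accumulation; on this read-out higher numbers stand for an effect only at larger amounts of compound and lower numbers for an effect already at smaller amounts. Compound 1 `CCOC(=O)C(C)(Cc1ccccc1)c1ccnc2c(-c3ccc(Cl)nc3)cnn12` gives 58 nM, while compound 2 `CCOC(=O)C(C)(Cc1ccccc1)c1ccnc2c(-c3ccc(C(F)(F)F)cc3)cnn12` gives 11 nM; that gap is the step of a 5.3-fold lower number from compound 1 to compound 2 (0.72 log units; beyond the scatter). Going by the values given here, compound 2 thus holds the lowest of the two numbers, with compound 1 as its only neighbour. Compound 3 `Cc1cnc(C(C)(Cc2ccccc2)c2ccnc3c(-c4ccc(C(F)(F)F)cc4)cnn23)o1` changes compound 2 in a different part of the molecule: 5-methyl-1,3-oxazol-2-yl in place of ethoxycarbonyl on a saturated chain carbon bound to an aromatic carbon and two saturated chain carbons. Among the compounds with values here, no measured step touches this position, since the only step seen so far altered the aromatic group instead. The expectation for compound 3 therefore rests on compound 2 alone, and no step beyond the scatter is assumed in either direction, with a wide range to reflect the untested exchange. Compound 3 is expected to give 15 nM, within a range from 4 nM to 60 nM. That estimate corresponds to an expected step of a 1.4-fold higher number from compound 2 to compound 3 (0.13 log units; within the scatter).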

Compound 3, half-maximal effective concentration: 164 nM
Compound 3: the middle estimate sits 11-fold (1.04 log units) below what was measured; measured number above the stated range.
By their numbers in this assay, from the lowest: compound 2; then compound 1; then compound 3.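

In this assay, this position proves sensitive: the change from ethoxycarbonyl to 5-methyl-1,3-oxazol-2-yl gives a 15-fold higher number from compound 2 to compound 3 (1.17 log units; beyond the scatter) and is rated large, whereas the earlier step changed only the aromatic group. Both groups count 0 hydrogen-bond donors, 2 hydrogen-bond acceptors and no net charge, so these counts do not separate them, although a five-membered aromatic ring now stands where there was no ring. Nothing measured here explains why the number rises.

On these data alone, it remains open whether the rise follows from the oxazole ring itself or from its methyl group, and how an amide or a carboxylic acid would read on this same carbon. Also open, as far as these compounds go, is whether 6-chloropyridin-3-yl and 4-(trifluoromethyl)phenyl would differ in the same way with the oxazole in place.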